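A few compounds are considered here, and "the series" means these few. Any claim that something is new, unique, unknown or untested is made for them only; others in the source may bear on it.

Results in a functional assay on cells (Homo sapiens) for inhibition, read by MTT assay, with a stated time of 48 h; a lower number here means a stronger inhibitor, a higher number a weaker inhibitor:
- Compound 1 `O=C(CCCCCCCOc1no[n+]([O-])c1S(=O)(=O)c1ccccc1)NO`: "not determined" (no result reported)
- Compound 2 `O=C(NO)c1ccc(Oc2no[n+]([O-])c2S(=O)(=O)c2ccccc2)cc1`: 4350 nM
- Compound 3 `COc1cc(C(=O)NO)ccc1Oc1no[n+]([O-])c1S(=O)(=O)c1ccccc1`: 1240 nM

Of the two numbers available, compound 2 holds the higher, so it is the weaker inhibitor of the pair. Compound 4 `O=C(/C=C/c1ccc(Oc2no[n+]([O-])c2S(=O)(=O)c2ccccc2)cc1)NO` differs from it as follows: 2-(hydroxycarbamoyl)ethenyl in place of hydroxycarbamoyl on an aromatic carbon. The hydroxycarbamoyl group thus gives way to 2-(hydroxycarbamoyl)ethenyl. For the measured compounds named here, no measured step covers this change. The nearest guide is a 3.5-fold lower number from compound 2 to compound 3 (0.55 log units; beyond the scatter), a modest step from a different change, methoxy in place of hydrogen. On that slender basis, a step of similar modest size towards a lower number is expected in this assay, though one within the scatter remains possible. The estimated step is a 2.2-fold lower number from compound 2 to compound 4 (0.34 log units; beyond the scatter). Compound 4 is expected at 2000 nM, with an estimated range from 500 nM to 8000 nM.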

Compound 4, half-maximal inhibitory concentration: 38100 nM
Beside the measured number, compound 4's estimate is 19-fold (1.28 log units) below it, and the stated range ends below it.
By their numbers in this assay, from the lowest: compound 3; then compound 2; then compound 4.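

In this assay, 2-(hydroxycarbamoyl)ethenyl in place of hydroxycarbamoyl on the aromatic carbon para to a large group brings an 8.8-fold higher number from compound 2 to compound 4 (0.94 log units; beyond the scatter). For the compounds shown here, the only earlier step, with methoxy, moved the number downward, whereas this change shows that altering the group that carries the hydroxycarbamoyl can move it clearly upward. Nothing given here accounts for this shift. The compounds shown leave open whether the double bond or the added length matters, which a saturated ethyl link bearing hydroxycarbamoyl could separate. They also leave open how a carboxylic acid would compare with hydroxycarbamoyl at this position.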